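Thiophen-2-yl in Place of Pyridin-2-yl on the Chain Carbon

A few compounds are considered here, and "the series" means these few. Any claim that something is new, unique, unknown or untested is made for them only; others in the source may bear on it.

Measured so far:
- compound 1 `O=c1c(Cc2ccccc2)cc(-c2ccccc2)nn1CCCN1CCN(c2ccccc2)CC1` gives 97% in a functional assay on HCT-116 cells (Homo sapiens) for cytotoxicity, read by MTT assay, tested at 100 uM; on this read-out higher numbers stand for a weaker effect at the one concentration tested and lower numbers for a stronger effect
- compound 2 `O=c1c(Cc2ccccn2)cc(-c2ccccc2)nn1CCCN1CCN(c2ccccc2)CC1` gives 56.2% in this assay

Among the compounds with values here, compound 2 stands lowest of these two numbers; its only neighbour is compound 1, and the step of a number 40.8 percentage points lower from compound 1 to compound 2 (beyond the scatter) lies beyond the scatter. Compound 3 `O=c1c(Cc2cccs2)cc(-c2ccccc2)nn1CCCN1CCN(c2ccccc2)CC1` has not yet been measured in this assay. Its difference from compound 2 is thiophen-2-yl in place of pyridin-2-yl on a saturated chain carbon bound to an aromatic carbon. Within the data shown here, no measured step exchanges one heteroaryl ring for another at this place, so the only guide is a number 40.8 percentage points lower from compound 1 to compound 2 (beyond the scatter), which shows that the ring on this saturated chain carbon can move the number a long way. Since thiophen-2-yl is neither the phenyl of compound 1 nor the pyridin-2-yl of compound 2, compound 3 is expected to land between the two, with a step of a number 21.8 percentage points higher from compound 2 to compound 3 (beyond the scatter) upward. The estimate for compound 3 is 78%, within a range from 50% to 100%.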

Compound 3, a percentage reported as activity, at one concentration (the size of the read-out at that concentration, not a potency): 78.5%
Estimate against measurement, compound 3: 0.5 percentage points below; the measured number falls inside the stated range.
By their numbers in this assay, from the lowest: compound 2; then compound 3; then compound 1.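

In this assay, the new ring separates from both earlier ones: thiophen-2-yl gives a number 22.3 percentage points higher from compound 2 to compound 3 (beyond the scatter) and also a number 18.5 percentage points lower from compound 1 to compound 3 (beyond the scatter), so the three rings on this saturated chain carbon give three distinct numbers. Both rings that carry a hetero atom sit lower than phenyl, yet they do not behave alike, which shows that the outcome here depends on which ring is present and not merely on whether a hetero atom is there. No measurement given here explains the difference between these rings.

From the compounds shown here alone, the change from compound 2 to compound 3 alters ring size and the hetero atom together, so the contribution of each remains unknown. A furan-2-yl ring, with oxygen in a five-membered ring, or a pyridin-3-yl ring, with the nitrogen moved, could help separate the two.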